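The source may hold more compounds than are shown below. What is called first, only, known or untested is meant among the compounds shown, and "the series" means these compounds.

Of the compounds shown here, three from this series have been measured in a physicochemical assay for solubility, in phosphate buffer, measured as kinetic solubility, with a stated time of 1 h, at pH 7.4; on this read-out higher numbers stand for higher solubility and lower numbers for lower solubility. Compound 1 `COc1ccc2nc(C)cc(OCC(=O)NCc3cc(C)cc(C)c3)c2c1` gives 92000 nM, compound 2 `COc1ccc2nc(C)cc(OCC(=O)Nc3ccc(Cl)c(OC)c3)c2c1` gives 13000 nM, and compound 3 `COc1ccc2nc(C)cc(OCC(=O)Nc3ccccn3)c2c1` gives 29000 nM. On these numbers compound 3 stands second highest: it sits a 2.2-fold higher number from compound 2 to compound 3 (0.35 log units; beyond the scatter) above compound 2, and a 3.2-fold lower number from compound 1 to compound 3 (0.50 log units; beyond the scatter) below compound 1.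

Compound 4 `COc1ccc2nc(C)cc(OCC(=O)Nc3nc(C)c(C)s3)c2c1` differs from compound 3 in one place: 4,5-dimethyl-1,3-thiazol-2-yl in place of pyridin-2-yl on an amide-type nitrogen. For the measured compounds named here, no measured step swaps exactly these two groups, so the expectation rests on neighbouring steps. The swap of the 3,5-dimethylbenzyl group for a six-membered ring gave a 3.2-fold lower number from compound 1 to compound 3 (0.50 log units; beyond the scatter) and a 7.1-fold lower number from compound 1 to compound 2 (0.85 log units; beyond the scatter), and the swap between the two six-membered rings gave a 2.2-fold higher number from compound 2 to compound 3 (0.35 log units; beyond the scatter). Each change of the group on the amide-type nitrogen moved this assay by a modest amount, and the benzyl-bearing compound 1 stayed highest. For compound 4 a modest drop is therefore expected, of about a 2.2-fold lower number from compound 3 to compound 4 (0.35 log units; beyond the scatter), since the 4,5-dimethyl-1,3-thiazol-2-yl group is the larger of the two rings being compared. Compound 4 is thus estimated at 13000 nM in this assay, with a plausible range from 4500 nM to 38000 nM.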

Compound 4, solubility: 31500 nM
Compound 4: middle estimate off by 2.4-fold (0.38 log units), on the low side, and the stated range covers the measured number.
By their numbers in this assay, from the lowest: compound 2; then compounds 3 and 4 (each within the scatter of the next); then compound 1.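

In this assay, the 4,5-dimethyl-1,3-thiazol-2-yl group and the pyridin-2-yl group on the amide-type nitrogen cannot be told apart, with a 1.1-fold higher number from compound 3 to compound 4 (0.04 log units; within the scatter) as the step between them, so on this position a five-membered aromatic ring with sulfur in it can take the place of a six-membered one without a change beyond the scatter. The new ring also keeps the same standing against the other two groups, with a 2.4-fold higher number from compound 2 to compound 4 (0.38 log units; beyond the scatter) on one side and a 2.9-fold lower number from compound 1 to compound 4 (0.47 log units; beyond the scatter) on the other, which places it with pyridin-2-yl, clear of both the 4-chloro-3-methoxyphenyl and the 3,5-dimethylbenzyl compounds. No supporting data are given that would explain this result.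

As far as these compounds go, whether the number stays in this range for a plain 1,3-thiazol-2-yl without its two methyl groups, or for a ring carrying an amine or a carboxylic acid, remains open. The compounds shown also differ only in the group on the amide-type nitrogen, so they say nothing about what a change in the shared core would do.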